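The source may hold more compounds than are shown below. What is called first, only, known or untested is meant among the compounds shown, and "the series" means these compounds.

Compound 1 `NS(=O)(=O)CC(=O)NCCSc1nonc1/C(=N/O)Nc1cccc(C(F)F)c1` is the reference point of the set. In an ADME assay on isolated protein for pharmacokinetics, with UDP-glucuronosyltransferase 1A9 (Homo sapiens) as the target, read by LC-MS, with a stated time of 60 min, at 37 degrees C, tested at 1 uM, in the presence of a further agent that is not named here (on this read-out lower numbers stand for a shorter-lived compound and higher numbers for a longer-lived compound), compound 1 gives > 3 h, which is a limit of the assay and not a number. Compound 2 `CC1(C(=O)NCCSc2nonc2/C(=N/O)Nc2ccc(F)c(C(F)F)c2)CCN1` is read the same way, and in this assay compound 2 gives > 3 h, again a limit. Compound 3 `C[C@@H](CSc1nonc1/C(=N/O)Nc1ccc(F)c(Br)c1)NC(=O)CS(N)(=O)=O` in this assay gives > 3 h, also a limit. Within the data shown here, all measured values rest at the limit of > 3 h in this assay, at which 3 of the 3 values shown sit, so compound 1 stands exactly where the rest of the measured set stands, and no step between measured compounds can be drawn. Compound 4 `N#Cc1cc(N/C(=N\O)c2nonc2SCCNC(=O)CS(N)(=O)=O)ccc1F` differs from compound 1 by 3-cyano-4-fluorophenyl in place of 3-(difluoromethyl)phenyl on an amine nitrogen. Without any measured step to lean on, the expected step that the limit leaves unreadable from compound 1 to compound 4 in this assay is none beyond the scatter. Compound 4 is therefore estimated at 4 h in this assay, within 2 h to 8 h, most probably returned once more as a limit.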

Compound 4, half-life: > 3 h
Compound 4 ended at the assay's limit (the forecaster's own chance of this, stated with the estimate: 80%); the middle value does not contradict the limit.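

In this assay no step can be read from compound 1 to compound 4, as both values are limits of the assay: the limit of > 3 h in this assay, at which 4 of the 4 values shown sit.

The compounds shown leave open how long any of them actually lasts, and whether 3-cyano-4-fluorophenyl in place of 3-(difluoromethyl)phenyl changes half-life at all.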